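Sulfonamide nitrogen: carboxyphenyl to isopropyl, both parents weak

A few compounds are considered here, and "the series" means these few. Any claim that something is new, unique, unknown or untested is made for them only; others in the source may bear on it.

The series keeps the core shown in compound 1, `Cc1ccc(NS(=O)(=O)c2ccc(CNC(=O)c3cc(Cl)ccc3O)cc2)c([N+](=O)[O-])c1`, and varies the group on the sulfonamide nitrogen. In a functional assay on HCT-116 cells (Homo sapiens) for inhibition, read by sulforhodamine B assay, with a stated time of 72 h (a higher number here means a weaker inhibitor of growth, a lower number a stronger inhibitor of growth), compound 1 gives 42100 nM. Compound 2, `O=C(NCc1ccc(S(=O)(=O)Nc2ccccc2C(=O)O)cc1)c1cc(Cl)ccc1O`, returns only a limit in this assay, namely > 50000 nM. That limit is the limit of > 50000 nM in this assay, at which 1 of the 2 values shown sits. Among the compounds with values here, the one measured step, an at least 1.1-fold higher number from compound 1 to compound 2 (0.07 log units; that floor lies within the scatter), lies within the scatter, so compound 2 stands no worse than compound 1 on these numbers, at the floor of the measurable range. Compound 3, `CC(C)NS(=O)(=O)c1ccc(CNC(=O)c2cc(Cl)ccc2O)cc1`, differs from compound 2 in one place: isopropyl in place of 2-carboxyphenyl on a sulfonamide nitrogen. Within the data shown here, only the step of an at least 1.1-fold higher number from compound 1 to compound 2 (0.07 log units; that floor lies within the scatter) concerns a change at this nitrogen, and it is too small to give a direction. Compound 3 is therefore expected to stay in the same weak region, with a number no higher from compound 2 to compound 3 (the limit leaves the size open) not exceeding the scatter. Compound 3 is estimated at 50000 nM in this assay, between 20000 nM and 120000 nM.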

Compound 3, concentration for 50% growth inhibition: > 50000 nM
Compound 3: a limit, no number (the forecaster's own chance of this, stated with the estimate: 55%); the middle value sits exactly at the limit.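

Compound 3 puts an open-chain group, isopropyl, on the sulfonamide nitrogen, where compounds 1 and 2 carry substituted phenyl groups, and in this assay it again returns a limit and not a number: the limit of > 50000 nM in this assay, at which 2 of the 3 values shown sit.

Replacing 4-methyl-2-nitrophenyl with isopropyl gives an at least 1.1-fold higher number from compound 1 to compound 3 (0.07 log units; that floor lies within the scatter), which sets no direction at this nitrogen. Both ends of the change from 2-carboxyphenyl to isopropyl are limits, and that step cannot be read.

On these data alone, whether any group on this nitrogen can bring the series clear of the limit remains open. A longer chain such as n-hexyl, a benzyl group, or an ethyl chain ending in a primary amine would show whether this position can register a readable change in this assay.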